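The compounds below may be only part of what the source reports. "The series", "measured", "known", "first", "only" and "open" are said of these compounds alone.

Three compounds share a core in which a heteroaromatic group sits on a saturated carbon bound to an amide-type nitrogen, while a sulfonyl sulfur on the far side carries a further group. Compound 1 `O=C(NCc1cnccn1)Nc1ccc(S(=O)(=O)c2ccccc2)cc1` in an assay on isolated protein for inhibition of Nicotinamide phosphoribosyltransferase (Homo sapiens), read by spectrophotometry, with stated times of 15 min and 30 min (a higher number here means a weaker inhibitor, a lower number a stronger inhibitor), gives 1300 nM. Compound 2 `Nc1ncc(CNC(=O)Nc2ccc(S(=O)(=O)c3ccccc3)cc2)cn1` changes only the heteroaromatic group, and in this assay compound 2 gives 14 nM; the step of a 93-fold lower number from compound 1 to compound 2 (1.97 log units; beyond the scatter) shows that this part of the molecule can move the number a great deal. Compound 3 `C[C@@H]1COC[C@@H](C)N1S(=O)(=O)c1ccc(NC(=O)NCc2cccnc2)cc1` carries a 3,5-dimethylmorpholin-4-yl on the sulfonyl sulfur and yet another heteroaromatic group; in this assay compound 3 gives 52 nM, the second highest of the three numbers, sitting between compound 2 and compound 1.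

Compound 4 `O=C(NCc1cccnc1)Nc1ccc(S(=O)(=O)N2CCCNCC2)cc1` keeps everything of compound 3 except at the sulfonyl sulfur: 1,4-diazepan-1-yl in place of 3,5-dimethylmorpholin-4-yl on a sulfonyl sulfur. For the measured compounds named here, no measured step touches the group on the sulfonyl sulfur; the only measured step concerns the heteroaromatic group and so does not bear on this change. Without any guide, the expectation is that the step of a 1.2-fold higher number from compound 3 to compound 4 (0.06 log units; within the scatter) stays within the scatter, in no clear direction. Compound 4 is therefore estimated at 60 nM, with a likely range from 20 nM to 200 nM.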

Compound 4, half-maximal inhibitory concentration: 45 nM
Estimate against measurement, compound 4: 1.3-fold (0.12 log units) above; the measured number falls inside the stated range.
By their numbers in this assay, from the lowest: compound 2; then compounds 4 and 3 (each within the scatter of the next); then compound 1.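

In this assay, for the compounds shown here, the step of a 1.2-fold lower number from compound 3 to compound 4 (0.06 log units; within the scatter) is the only measured change to the group on the sulfonyl sulfur, and it shows that two quite different rings at this position cannot be told apart by their numbers. The 3,5-dimethylmorpholin-4-yl is a six-membered ring with an oxygen, 2 defined stereocentres and no hydrogen-bond donor, while the 1,4-diazepan-1-yl is a seven-membered ring with a second nitrogen, 1 hydrogen-bond donor and no stereocentres, so in this one pair these differences together leave no mark beyond the scatter. No measurement is at hand that explains why the two groups read alike.

The compounds shown leave open whether this tolerance reaches much smaller or differently built groups on the sulfonyl sulfur, such as a simple dimethylamino group or a piperidine bearing a carboxylic acid. They also leave open whether the 2-aminopyrimidin-5-yl group, so influential in the pair of compounds carrying a phenyl on the sulfonyl sulfur, would have a similar influence alongside the 1,4-diazepan-1-yl of compound 4.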